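Replacing the dichlorophenyl group of compound 1

The source may report more compounds than this note shows. Statements on the series, on what has been measured and on what is new or still open speak of the compounds shown alone.

Compound 1 `O=C(Nc1cccc(-n2cc(-c3ccncc3)c(-c3ccc(Cl)c(O)c3)n2)c1)Nc1ccc(Cl)c(Cl)c1`: > 32500 nM in a functional assay on MDA-MB-468 cells (Homo sapiens) for inhibition, read by sulforhodamine B assay, with a stated time of 48 h; a higher number here means that more compound is tolerated, a lower number that less compound is tolerated
Compound 2 `COc1cc(-c2nn(-c3cccc(NC(=O)c4ccccc4)c3)cc2-c2ccncc2)ccc1Cl`: > 100000 nM

Both results are limits of the assay rather than numbers. For compound 1 the reading in this assay is the limit (the limit of > 32500 nM in this assay, at which 1 of the 2 values shown sits). For compound 2 the reading is the limit (the limit of > 100000 nM in this assay, at which 1 of the 2 values shown sits). Compound 1 therefore sits at a limit, and its position among the values shown cannot be fixed more closely; the two limits cannot be ordered against each other.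

Compound 3 `O=C(Nc1cccc(-n2cc(-c3ccncc3)c(-c3ccc(Cl)c(O)c3)n2)c1)Nc1cccc(C(F)(F)F)c1` differs from compound 1 in one place: 3-(trifluoromethyl)phenyl in place of 3,4-dichlorophenyl on an amide-type nitrogen. Going by the values given here, no measured pair of compounds shares this change, so nothing points to a step beyond the scatter, and the step that the limit leaves unreadable from compound 1 to compound 3 is expected to be small. Compound 3 is accordingly expected near 40000 nM, within 12000 nM to 150000 nM, with a real chance that only a limit is again reported.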

Compound 3, concentration lethal to 50% of the cells: > 32500 nM
Compound 3 was reported as a limit; the forecaster's own chance of this, stated with the estimate: 65%; the middle value does not contradict the limit.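

In this assay compound 1 and compound 3 are both reported only as limits, so no step can be read between them. The compounds shown leave open whether 3-(trifluoromethyl)phenyl in place of 3,4-dichlorophenyl on an amide-type nitrogen changes the reading at all.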